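Adding a Second Methyl at the Hydroxyl-Bearing Carbon

This account rests on a few compounds, and the source may have more. Where it says the series, first, only, none or still open, it means among the compounds named here.

Three measured compounds share one core and differ only in the small side chain attached through an oxygen to a saturated ring. Compound 1 `COCCOC1CCN(c2nc(N)c3cc(OC)c(OC)cc3n2)CC1` gives 2.12 nM in an assay on brain for displacement of a labelled ligand from Adrenergic receptor alpha-1 (Rattus norvegicus); on this read-out higher numbers stand for weaker inhibition and lower numbers for stronger inhibition. Compound 2 `COc1cc2nc(N3CCC(OCCO)CC3)nc(N)c2cc1OC` gives 2.2 nM, and compound 3 `COc1cc2nc(N3CCC(OCC(C)O)CC3)nc(N)c2cc1OC` gives 3.52 nM. Compound 3 carries the largest of the three numbers, yet its gaps to both neighbours stay within the scatter: a 1.7-fold higher number from compound 1 to compound 3 (0.22 log units; within the scatter) and a 1.6-fold higher number from compound 2 to compound 3 (0.20 log units; within the scatter). Likewise a 1.0-fold higher number from compound 1 to compound 2 (0.02 log units; within the scatter) shows no change beyond the scatter.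

Compound 4 `COc1cc2nc(N3CCC(OCC(C)(C)O)CC3)nc(N)c2cc1OC` has not yet been measured. Relative to compound 3 the change is methyl in place of hydrogen on a saturated chain carbon bound to an oxygen on a saturated carbon and two saturated chain carbons. Going by the values given here, the step from compound 2 to compound 3 is the closest precedent, since it placed the first methyl on that same carbon, and it moved the number only within the scatter. The other two steps in this set were equally small. On that basis the second methyl is expected to shift the number by little, perhaps nudging it slightly higher, with a step estimated at a 1.3-fold higher number from compound 3 to compound 4 (0.11 log units; within the scatter). Compound 4 is therefore expected to give about 4.5 nM, with a likely range from 2 nM to 10 nM.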

Compound 4, inhibition constant: 1.28 nM
Estimate against measurement, compound 4: 3.5-fold (0.55 log units) above; measured number outside the range, below it.
By their numbers in this assay, from the lowest: compounds 4, 1, 2 and 3 (each within the scatter of the next, the first and the last beyond it).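

Going by these compounds alone, at this carbon, the first and second methyl do not behave alike in this assay: the second gives a 2.8-fold lower number from compound 3 to compound 4 (0.44 log units; beyond the scatter), the only step in this set that lies beyond the scatter. Compared with the other two side chains, the 2-hydroxy-2-methylpropoxy group shows a 1.7-fold lower number from compound 2 to compound 4 (0.24 log units; within the scatter) and a 1.7-fold lower number from compound 1 to compound 4 (0.22 log units; within the scatter), so a carbon bearing the hydroxyl and two methyls keeps the number level with those of compound 1 and compound 2, and only the 2-hydroxypropoxy group of compound 3 stands apart from it. Nothing available here accounts for the step, so why the second methyl has this effect remains unknown.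

Still open, as far as these compounds go, is whether the hydroxyl is needed once both methyls are present, for instance whether an amine or a methoxy group on that same carbon would give a number close to that of compound 4. It is equally unclear whether an ethyl in place of one methyl, or a longer chain carrying the same branched carbon, would keep the number in this region.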